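Adding a Cyano Chain to a Compound at the Assay Limit

This account rests on a few compounds, and the source may have more. Where it says the series, first, only, none or still open, it means among the compounds named here.

Compound 1, `CCCCN1CCN(C(=S)SC(=S)N(C)C)CC1`, gives 4100000 nM in an ADME assay on HeLa cells (Homo sapiens) for cytotoxicity, read by MTT assay, with a stated time of 24 h; a lower number here means a stronger inhibitor, a higher number a weaker inhibitor.
Compound 2, `CSC(=S)N1CCN(C(=S)SC(=S)N(C)C)CC1`, gives > 5000000 nM in this assay, a limit of the assay rather than a number.

Among the measured compounds shown here, compound 2 therefore sits at the limit of > 5000000 nM in this assay, at which 1 of the 2 values shown sits, and the one measured step, an at least 1.2-fold higher number from compound 1 to compound 2 (0.08 log units; that floor lies within the scatter), sits at a floor within the scatter. Compound 3, `CN(C)C(=S)SC(=S)N1CCN(C(=S)SCCCC#N)CC1`, differs from compound 2 by 2-cyanoethyl in place of hydrogen on a saturated chain carbon bound to a sulfur. For the measured compounds named here, no measured step covers such a change, so no shift beyond the scatter is expected; the expected change is a number no higher from compound 2 to compound 3 (the limit leaves the size open). Compound 3 is estimated at 5000000 nM, within 2000000 nM to 15000000 nM, most likely again reported only as a limit.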

Compound 3, half-maximal inhibitory concentration: > 5000000 nM
Compound 3: only a limit was reported; the forecaster's own chance of this, stated with the estimate: 60%; the middle value lies on the limit itself.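

Among the compounds shown here, compound 2 and compound 3 are both reported in this assay only as limits, so no step between them can be read: the limit of > 5000000 nM in this assay, at which 2 of the 3 values shown sit.

From the compounds shown here alone, whether 2-cyanoethyl in place of hydrogen changes the number at all, and in which direction, stays open.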